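A Triazole Replaces the Aminothiazole on the Sulfur-Bound Arm

The source may report more compounds than this note shows. Statements on the series, on what has been measured and on what is new or still open speak of the compounds shown alone.

In an assay on CHO cells for displacement of a labelled ligand from adenosine receptor A3 (Homo sapiens), read by scintillation counting, with a stated time of 120 min, tested at 1 uM (a lower number here means less inhibition, a higher number more inhibition at the concentration tested (going by the name of the read-out)), the measured compounds gave these readings:
Compound 1, `COC(=O)c1cccc(CSc2nc(N)c(C#N)c(-c3ccc(OCC4CC4)cc3)c2C#N)c1`: 4%
Compound 2, `N#Cc1c(N)nc(SCn2cncn2)c(C#N)c1-c1ccc(OCC2CC2)cc1`: 1%
Compound 3, `N#Cc1c(N)nc(SCc2csc(N)n2)c(C#N)c1-c1ccc(OCC2CC2)cc1`: 1%

All three share one core and differ only in the group carried on a saturated chain carbon bound to a sulfur. Compound 3 stands level with compound 2, and together they are the lowest of the three numbers; the step of no change at the digits printed from compound 2 to compound 3 (within the scatter) shows no change at the digits printed, and the step of a number 3 percentage points lower from compound 1 to compound 3 (within the scatter) is likewise within the scatter. None of the three compounds shows meaningful inhibition at the concentration tested.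

Compound 4, `N#Cc1c(N)nc(SCc2ncn[nH]2)c(C#N)c1-c1ccc(OCC2CC2)cc1`, is the next variation of the same arm: 1H-1,2,4-triazol-5-yl in place of 2-amino-1,3-thiazol-4-yl on a saturated chain carbon bound to a sulfur

Among the measured compounds shown here, the steps that bear on this change are a number 3 percentage points lower from compound 1 to compound 2 (within the scatter), a number 3 percentage points lower from compound 1 to compound 3 (within the scatter) and no change at the digits printed from compound 2 to compound 3 (within the scatter): three different groups in this position, all leaving the reading near zero and all within the scatter. On that basis the expected step of a number 1 percentage points higher from compound 3 to compound 4 (within the scatter) is none beyond the scatter. Compound 4 is therefore estimated at 2%, with a range from -8% to 12%.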

Compound 4, a percentage reported as inhibition, at one concentration (the size of the read-out at that concentration, not a potency): 1%
Beside the measured number, compound 4's estimate is 1 percentage points above it, and the stated range covers the measured number.
By their numbers in this assay, from the lowest: compounds 2, 3, 4 and 1 (each within the scatter of the next).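

In this assay, putting 1H-1,2,4-triazol-5-yl in place of 2-amino-1,3-thiazol-4-yl on a saturated chain carbon bound to a sulfur gives no change at the digits printed from compound 3 to compound 4 (within the scatter), so a fourth group now leaves the reading where the other three stand. Among the compounds shown here, the new compound also tests how the same triazole is attached, a point the earlier compounds did not touch: the 1H-1,2,4-triazol-5-yl and 1H-1,2,4-triazol-1-yl forms give no change at the digits printed from compound 2 to compound 4 (within the scatter), and the comparison with the 3-(methoxycarbonyl)phenyl group gives a number 3 percentage points lower from compound 1 to compound 4 (within the scatter), so neither the attachment point of the triazole nor a switch to the larger group separates these compounds in this assay. Nothing measured alongside these readings offers an explanation for them.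

All four readings come from a single concentration and sit within the scatter of one another, so they give no ranking of the groups at this position. Still open, going by these compounds, is whether a carboxylic acid in place of the methyl ester on the phenyl ring, a simple amine on the chain carbon, or a longer chain between the sulfur and the ring would give a reading clearly different from these.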